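A few compounds are considered here, and "the series" means these few. Any claim that something is new, unique, unknown or untested is made for them only; others in the source may bear on it.

Three compounds have been measured in an ADME assay on microsomes from liver (Homo sapiens) for metabolic stability, read by LC-MS, tested at 1 uM (a higher number here means that the compound lasts longer, a lower number that the compound disappears faster), so far:

compound 1 `CCOC(=O)c1cc(-c2csc(Nc3ccc(C)cc3)n2)on1` gives < 0.0167 h (a limit of the assay)
compound 2 `CCOC(=O)c1cc(-c2csc(Nc3cc(Cl)cc(Cl)c3)n2)on1` gives 0.055 h
compound 3 `Cc1ccc(Nc2nc(-c3cc(C(=O)O)no3)cs2)cc1` gives 0.238 h

Compound 3 carries the highest number of the three, and its value stands clear of compound 2 (0.055 h). Compound 4 `Cc1ccc(Nc2nc(-c3cc(C(=O)Nc4ccccn4)no3)cs2)cc1` differs from compound 3 by (pyridin-2-yl)amino in place of hydroxy on a carbonyl carbon on a carbonyl carbon, with (pyridin-2-yl)amino in place of hydroxy. The step that bears on this change sits on the same carbonyl group, where hydrogen in place of ethyl gave an at least 14-fold higher number from compound 1 to compound 3 (1.15 log units; beyond the scatter) and was large. Compound 4 gives up that hydroxy, so part of this gain is expected to be lost in this assay and a moderate fall is foreseen. The expected change is a 3.0-fold lower number from compound 3 to compound 4 (0.47 log units; beyond the scatter) in this reading. Compound 4 is estimated at 0.08 h with an expected range from 0.025 h to 0.25 h overall.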

Compound 4, half-life: 0.268 h
Compound 4: the middle estimate sits 3.4-fold (0.53 log units) below what was measured; measured number outside the range, above it.
By their numbers in this assay, from the lowest: compound 2; then compounds 3 and 4 (each within the scatter of the next). At a limit, below all of these: compound 1.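

In this assay, (pyridin-2-yl)carbamoyl in place of carboxy on this carbonyl carbon gives a 1.1-fold higher number from compound 3 to compound 4 (0.05 log units; within the scatter), so the hydroxy is not needed to hold the number at this level. Replacing ethoxy with (pyridin-2-yl)amino gives an at least 16-fold higher number from compound 1 to compound 4 (1.20 log units; beyond the scatter), a gain as clear as the one seen with hydroxy. That step starts from a limit, which compound 1 gives: the limit of < 0.0167 h in this assay, at which 1 of the 4 values shown sits.

The compounds shown leave open whether the ring of the (pyridin-2-yl)amino group matters, which a plain carboxamide or a phenylcarbamoyl group on this carbonyl carbon would address. They also leave open how (pyridin-2-yl)carbamoyl behaves together with the 3,5-dichlorophenyl group of compound 2.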